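The compounds below may be only part of what the source reports. "The series", "measured", "known", "first", "only" and "open" are said of these compounds alone.

Measured compounds:
Compound 1 `COc1cc(N(Cc2ccc(F)cc2)S(=O)(=O)c2ccc(C)cc2)cc(OC)c1OC` gives 3750 nM in a functional assay on MGC-803 cells (Homo sapiens) for inhibition, read by MTT assay, with a stated time of 48 h; on this read-out higher numbers stand for weaker inhibition and lower numbers for stronger inhibition.
Compound 2 `COc1cc(N(Cc2ccccc2)S(=O)(=O)c2ccc(C)cc2)cc(OC)c1OC` gives 3570 nM in this assay.
Compound 3 `COc1cc(N(Cc2nc3ccccc3[nH]2)S(=O)(=O)c2ccc(C)cc2)cc(OC)c1OC` gives 1020 nM in this assay.

Compound 3 holds the lowest of the three numbers, and its steps to both neighbours lie beyond the scatter: a 3.7-fold lower number from compound 1 to compound 3 (0.57 log units; beyond the scatter) and a 3.5-fold lower number from compound 2 to compound 3 (0.54 log units; beyond the scatter), whereas a 1.1-fold lower number from compound 1 to compound 2 (0.02 log units; within the scatter). Compound 4 `COc1cc(N(Cc2nc3ccccc3[nH]2)C(=O)c2ccc(C)cc2)cc(OC)c1OC` keeps the whole of compound 3 apart from one change: (4-methylphenyl)carbonyl in place of (4-methylphenyl)sulfonyl on a nitrogen on an aromatic ring. None of the three measured steps touches this part of the molecule; each of them alters only the group on the saturated chain carbon bound to the sulfonamide nitrogen, so none of them gives direct guidance on what the (4-methylphenyl)carbonyl will do in place of the (4-methylphenyl)sulfonyl. Among the measured compounds shown here, with no measured step bearing on the change, the estimate for compound 4 in this assay is set close to compound 3 with a wide range, and the expected step is a 1.8-fold higher number from compound 3 to compound 4 (0.25 log units; within the scatter). Compound 4 is thus estimated at 1800 nM, within 600 nM to 6000 nM.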

Compound 4, half-maximal inhibitory concentration: 30500 nM
For compound 4 the middle estimate is 17-fold (1.23 log units) below the measured one, outside the stated range (above it).
By their numbers in this assay, from the lowest: compound 3; then compounds 2 and 1 (each within the scatter of the next); then compound 4.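

In this assay, the nitrogen on an aromatic ring proves a sensitive place: (4-methylphenyl)carbonyl in place of (4-methylphenyl)sulfonyl brings a 30-fold higher number from compound 3 to compound 4 (1.48 log units; beyond the scatter), a larger step than the one seen on the saturated chain carbon, a 3.5-fold lower number from compound 2 to compound 3 (0.54 log units; beyond the scatter). The 4-methylphenyl ring stays in both groups, so in this pair the number follows the exchange of the sulfonyl link for the carbonyl link, and the 1H-benzimidazol-2-yl group alone does not keep the number low. Nothing available explains why this exchange has so large an effect.

The compounds shown leave open whether the phenyl or 4-fluorophenyl compounds would respond in the same way to this exchange. They also leave open how a methylene link or a longer chain in place of the sulfonyl link would fare on this nitrogen.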